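Chloro in place of fluoro on compound 3

The source may hold more compounds than are shown below. What is called first, only, known or untested is meant among the compounds shown, and "the series" means these compounds.

In an in vitro ADME assay on microsomes from liver (Mus musculus) for pharmacokinetics, read by LC-MS, with a stated time of 10 min, tested at 1 uM (on this read-out lower numbers stand for slow clearance and higher numbers for fast clearance), compound 1 `CN1C[C@H](C(=O)Nc2ccc(C(F)(F)F)cc2)[C@@H](c2ccc(/C=C/C(=O)Nc3ccccc3N)cc2)C1` gives 23 mL/min/kg, compound 2 `CN1C[C@H](C(=O)Nc2cccc(F)c2)[C@@H](c2ccc(/C=C/C(=O)Nc3ccccc3N)cc2)C1` gives 56 mL/min/kg and compound 3 `CN1C[C@H](C(=O)Nc2ccc(F)c(F)c2)[C@@H](c2ccc(/C=C/C(=O)Nc3ccccc3N)cc2)C1` gives 46 mL/min/kg, which stands within the scatter of both others. Compound 4 `CN1C[C@H](C(=O)Nc2ccc(F)c(Cl)c2)[C@@H](c2ccc(/C=C/C(=O)Nc3ccccc3N)cc2)C1` differs from compound 3 by chloro in place of fluoro on an aromatic carbon, ortho to a fluoro group: chloro in place of fluoro on an aromatic carbon. Among the compounds with values here, no measured step makes this exchange. The closest is fluoro in place of hydrogen on an aromatic carbon, a 1.2-fold lower number from compound 2 to compound 3 (0.09 log units; within the scatter). Exchanging the whole group on the amide-type nitrogen gave a 2.0-fold higher number from compound 1 to compound 3 (0.30 log units; within the scatter) and a 2.4-fold higher number from compound 1 to compound 2 (0.39 log units; beyond the scatter), the latter alone beyond the scatter. No step beyond the scatter is therefore expected in this assay, and the estimated step is a 1.1-fold lower number from compound 3 to compound 4 (0.04 log units; within the scatter). Compound 4 is estimated at 42 mL/min/kg, with an expected range of 22 mL/min/kg to 75 mL/min/kg.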

Compound 4, clearance: 34 mL/min/kg
Compound 4: the middle estimate sits 1.2-fold (0.09 log units) above what was measured; low and high end bracket the measured number.
By their numbers in this assay, from the lowest: compounds 1, 4, 3 and 2 (each within the scatter of the next, the first and the last beyond it).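

In this assay, within the data shown here, the exchange of fluoro for chloro at this place gives a 1.4-fold lower number from compound 3 to compound 4 (0.13 log units; within the scatter) and is the first direct reading of a halogen exchange on this aromatic carbon. Set against the other groups on the amide-type nitrogen, the 3-chloro-4-fluorophenyl group gives a 1.6-fold lower number from compound 2 to compound 4 (0.22 log units; within the scatter) and a 1.5-fold higher number from compound 1 to compound 4 (0.17 log units; within the scatter) so that compound 4 lies within the scatter of all three earlier compounds. Nothing at hand explains these numbers. Left open is how a bromo group, a methoxy group or an amine would read at this place, and whether chloro would read the same without the fluoro group.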